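A larger ring group on an inactive nucleoside

This account rests on a few compounds, and the source may have more. Where it says the series, first, only, none or still open, it means among the compounds named here.

Measured so far in a functional assay on CCRF-CEM cells (Homo sapiens), read by MTT assay, with a stated time of 72 h; a higher number here means a weaker inhibitor, a lower number a stronger inhibitor:
Compound 1 `C#Cc1cn([C@@H]2O[C@H](CO)[C@@H](O)[C@H]2O)c2ncnc(N(C)C)c12` gives 90 nM
Compound 2 `O=c1[nH]cnc2c1c(-c1ccccc1)cn2[C@@H]1O[C@H](CO)[C@@H](O)[C@H]1O` gives > 100000 nM

The second entry is not a true number. Compound 2 sits at > 100000 nM as a limit of the assay, so its real potency was not determined and no inhibition strength can be read from it. This places compound 2 at the weak end of what this assay can report.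

Going by the values given here, compound 3 `O=c1[nH]cnc2c1c(-c1cc3ccccc3o1)cn2[C@@H]1O[C@H](CO)[C@@H](O)[C@H]1O` keeps the core of compound 2 and has 1-benzofuran-2-yl in place of phenyl on an aromatic carbon and this is the only change. The new group is a larger, two-ring aromatic group that also contains an oxygen atom.

Among the compounds with values here, no measured pair shows what such a swap does in this assay. The expected step of an at least 1.4-fold lower number from compound 2 to compound 3 (0.15 log units; that floor lies within the scatter) is small and, if it can be seen at all, points towards stronger inhibition. The estimated value for compound 3 is 70000 nM within an expected range of 15000 nM to 100000 nM and the assay may well report only a limit again.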

Compound 3, half-maximal inhibitory concentration: > 20000 nM
Compound 3 ended at the assay's limit; the forecaster's own chance of this, stated with the estimate: 70%; the middle value lies beyond the limit too.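

Compound 2 and compound 3 each end at a limit of the assay rather than at a true number, and no step can be read between them. The compounds shown leave open whether 1-benzofuran-2-yl in place of phenyl changes inhibition at all in this assay, and how weak either compound really is.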